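The source may report more compounds than this note shows. Statements on the series, on what has been measured and on what is new or still open speak of the compounds shown alone.

In an assay on isolated protein for inhibition of high affinity 3',5'-cyclic-AMP phosphodiesterase 7A (Homo sapiens), read by cAMP accumulation, with a stated time of 10 min (a higher number here means a weaker inhibitor, a lower number a stronger inhibitor), compound 1 `COc1nc2c(c(=O)n(C)c(=O)n2C)n1CC(=O)Nc1ccc(C(C)C)cc1` gives > 200000 nM, which is a limit of the assay rather than a number. Compound 3 `CCOc1nc2c(c(=O)n(C)c(=O)n2C)n1CC(=O)Nc1ccc(C(C)C)cc1` carries the change methyl in place of hydrogen on a saturated chain carbon bound to an oxygen on an aromatic ring and in this assay gives > 200000 nM, again a limit. The step that the two limits leave unreadable from compound 1 to compound 3 therefore cannot be read, because both values sit at the limit of > 200000 nM in this assay, at which 2 of the 3 values shown sit. Compound 2 `COc1nc2c(c(=O)n(C)c(=O)n2C)n1CCCC(=O)Nc1ccc(C(C)(C)C)cc1` is built on a different core; how its core differs from that of compound 1 is not broken down here. In this assay, for the measured compounds named here, compound 2 gives 19800 nM, the only number among the three measured compounds. Compound 4 `CCOc1nc2c(c(=O)n(C)c(=O)n2C)n1CCCC(=O)Nc1ccc(C(C)(C)C)cc1` is not yet measured; it differs from compound 2 by methyl in place of hydrogen on a saturated chain carbon bound to an oxygen on an aromatic ring, the same change made from compound 1 to compound 3. Since that earlier step is unreadable, the step from compound 2 to compound 4 is expected to be small, a 1.0-fold higher number from compound 2 to compound 4 (0.00 log units; within the scatter), resting on compound 2 at 19800 nM. For compound 4 the expected value in this assay is 20000 nM, between 7000 nM and 60000 nM.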

Compound 4, half-maximal inhibitory concentration: 54300 nM
Compound 4: middle estimate off by 2.7-fold (0.43 log units), on the low side, and the stated range covers the measured number.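

In this assay, methoxy to ethoxy on the core of compound 2 gives a 2.7-fold higher number from compound 2 to compound 4 (0.44 log units; beyond the scatter) and so a modestly weaker inhibitor. This is one readable step on one core, so it does not show that the change would act with the same size, or even the same direction, on another core. On the core of compound 1, the same change cannot be read, because compound 1 and compound 3 both give a limit of the assay rather than a number: the limit of > 200000 nM in this assay, at which 2 of the 4 values shown sit.

On these data alone, it remains open whether a longer chain, such as propoxy, would weaken inhibition further on the core of compound 2. An amine in place of the methoxy is also untested among the compounds shown here.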